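The source may report more compounds than this note shows. Statements on the series, on what has been measured and on what is new or still open speak of the compounds shown alone.

Measured so far:
- compound 1 `O=C1OCC[C@@H]1NC(=S)SCCOc1ccc([N+](=O)[O-])cc1`: in a functional assay on MGC-803 cells (Homo sapiens) for antiproliferative activity, read by MTT assay, with a stated time of 72 h (a higher number here means a weaker inhibitor, a lower number a stronger inhibitor), compound 1 reaches only the assay limit > 100000 nM.
- compound 2 `O=C1OCC[C@@H]1NC(=S)SCCOc1cccc2ccccc12`: in this assay compound 2 reaches only the assay limit > 64000 nM.
- compound 3 `O=C1OCC[C@@H]1NC(=S)SCCOc1ccccc1`: in this assay compound 3 gives 53800 nM.

Among the measured compounds shown here, compound 3 holds the only actual number in this assay; the other two values are limits and not numbers. For the measured compounds named here, the single step measured in one place is an at least 1.8-fold lower number from compound 1 to compound 3 (0.26 log units; that floor lies within the scatter), and its floor lies within the scatter, so it says no more than that compound 3 is not weaker than compound 1. The two limits are the limit of > 100000 nM in this assay, at which 1 of the 3 values shown sits, and (the limit of > 64000 nM in this assay, at which 1 of the 3 values shown sits); nothing else anchors the series.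

Compound 4 `O=C1OCC[C@@H]1NC(=S)SCCOc1ccccc1Cc1ccccc1` differs from compound 3 by benzyl in place of hydrogen on an aromatic carbon. Going by the values given here, no measured step adds a carbon group of this kind; the one step available removes a nitro group and gives no size for this change. The expectation therefore rests on compound 3 alone, near the edge of what the assay resolves. The expected step is a 1.5-fold lower number from compound 3 to compound 4 (0.19 log units; within the scatter), a change that is not expected to exceed the scatter with confidence in either direction. Compound 4 is estimated at 35000 nM, between 9000 nM and 110000 nM, with a real chance that only a limit is returned.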

Compound 4, half-maximal inhibitory concentration: 32300 nM
For compound 4 the middle estimate is 1.1-fold (0.03 log units) above the measured one; the measured number falls inside the stated range.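

In this assay, benzyl in place of hydrogen on an aromatic carbon, ortho to a large group, gives a 1.7-fold lower number from compound 3 to compound 4 (0.22 log units; within the scatter), so the two values cannot be told apart. Among the compounds shown here, this is the first one-place step that ends in an actual number at both compounds, rather than resting on a limit at one end, and it shows that this place on the six-membered aromatic ring can carry benzyl, with its 7 heavy atoms and its own aromatic ring, while the compound still returns a number and not a limit. Nothing shown here gives a reason for this result, and the two limits in the series do not bear on it.

Still open is whether any group at this place moves the number beyond the scatter, since a carboxylic acid, an aminomethyl group or a longer alkyl chain in place of benzyl does not appear among these compounds. Also open, as far as these compounds go, is whether benzyl would read the same on another carbon of the ring, or whether changes to the lactone-bearing end of the shared core would matter more than anything on the aromatic ring.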